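The compounds below may be only part of what the source reports. "The series", "measured", "known", "first", "only" and "open" are said of these compounds alone.

Compound 1 `N#Cc1cccc(-n2cc(COc3cccc(NC(=O)Nc4ccc(Cl)c(C(F)(F)F)c4)c3)nn2)c1` gives in a toxicity assay on MRC5 cells (Homo sapiens) for inhibition, read by MTT assay, with a stated time of 72 h (a higher number here means a weaker inhibitor, a lower number a stronger inhibitor), 2960 nM; compound 2 `O=C(Nc1cccc(OCc2cn(-c3cccc(Br)c3)nn2)c1)Nc1ccc(Cl)c(C(F)(F)F)c1` gives 11900 nM; compound 3 `O=C(Nc1cccc(OCc2cn(-c3ccc(Br)cc3)nn2)c1)Nc1ccc(Cl)c(C(F)(F)F)c1` gives 11000 nM.

Compound 3 stands second highest of the three numbers, next to compound 2, while the step from compound 1 was larger: a 3.7-fold higher number from compound 1 to compound 3 (0.57 log units; beyond the scatter). Compound 4 `O=C(Nc1cccc(OCc2cn(-c3ccccc3I)nn2)c1)Nc1ccc(Cl)c(C(F)(F)F)c1` differs from compound 3 by 2-iodophenyl in place of 4-bromophenyl on an aromatic nitrogen. The step that bears most on this change, a 1.1-fold lower number from compound 2 to compound 3 (0.03 log units; within the scatter), moved the bromine around the ring and stayed within the scatter; the exchange of the whole aryl group, a 3.7-fold higher number from compound 1 to compound 3 (0.57 log units; beyond the scatter), was only modest. For the measured compounds named here, no measured pair covers bromine against iodine. The expected step is therefore small, a 1.1-fold lower number from compound 3 to compound 4 (0.04 log units; within the scatter), with no direction beyond the scatter. Compound 4 is estimated in this assay at 10000 nM, ranging from 4000 nM to 25000 nM.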

Compound 4, half-maximal inhibitory concentration: 21900 nM
Estimate against measurement, compound 4: 2.2-fold (0.34 log units) below; the measured number falls inside the stated range.
By their numbers in this assay, from the lowest: compound 1; then compounds 3, 2 and 4 (each within the scatter of the next).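

In this assay, the 2-iodophenyl group on the aromatic nitrogen stays within the scatter of both bromophenyl compounds (a 2.0-fold higher number from compound 3 to compound 4 (0.30 log units; within the scatter)) and (a 1.8-fold higher number from compound 2 to compound 4 (0.26 log units; within the scatter)), so these three halogen-bearing aryl compounds cannot be told apart here. Against the 3-cyanophenyl group the step remains modest but lies beyond the scatter (a 7.4-fold higher number from compound 1 to compound 4 (0.87 log units; beyond the scatter)). No measurement at hand accounts for these numbers. Compound 4 changes both the halogen and its ring position relative to compound 2 and compound 3, so a 2-bromophenyl or 4-iodophenyl group would be needed to separate the two changes. On these data alone, how an aryl group carrying an amine or a carboxylic acid would read in this assay also stays open.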